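The source may report more compounds than this note shows. Statements on the series, on what has been measured and on what is new or still open speak of the compounds shown alone.

Of the compounds shown here, three have so far been measured in a functional assay on MOLT-4 cells (Homo sapiens) for inhibition, read by sulforhodamine B assay, with a stated time of 48 h, tested at 10 uM; a lower number here means less inhibition of growth, a higher number more inhibition of growth at the concentration tested. In this assay compound 1 `c1ccc(-c2nc3sc(-c4ccccc4)cn3n2)cc1` gives 11%, compound 2 `CC(=O)c1ccc(NC(=O)Cn2nc(-c3ccc(Cl)cc3)nc2N)cc1` gives 16.5%, and compound 3 `COc1ccc(-c2nc3sc(-c4ccc(Cl)cc4)cn3n2)cc1` gives 17.4%. Compound 3 carries the highest of the three numbers, yet its gaps to compound 2 and to compound 1 both lie within the usual scatter, so these data do not separate the three. Compound 4 `Clc1ccc(-c2cn3nc(-c4ccccc4)nc3s2)cc1` shares the core of compound 3 and differs from it in one place: hydrogen in place of methoxy on an aromatic carbon. For the measured compounds named here, no measured pair shows this change on its own. The step from compound 3 to compound 4 is expected to stay within the scatter, a number 3.4 percentage points lower from compound 3 to compound 4 (within the scatter). Compound 4 is therefore estimated at 14%, within a range from 4% to 25%.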

Compound 4, percent growth inhibition at one concentration: 8%
The estimate for compound 4 lay 6 percentage points above the measured number; low and high end bracket the measured number.
By their numbers in this assay, from the lowest: compounds 4, 1, 2 and 3 (each within the scatter of the next).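

In this assay, for the compounds shown here, hydrogen in place of methoxy on an aromatic carbon, para to a large group, gives a number 9.4 percentage points lower from compound 3 to compound 4 (within the scatter), the first direct reading of this change, and it cannot be told apart from no effect at this position. Chloro in place of hydrogen on an aromatic carbon, a second single change, gives a number 3 percentage points lower from compound 1 to compound 4 (within the scatter), so it also shows no separable effect. Nothing available explains either step. On these data alone, whether an amine or a carboxylic acid at the methoxy position would move the number beyond the scatter remains open.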